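Swapping a methoxyphenoxy arm for a methylpyridinyl arm

A few compounds are considered here, and "the series" means these few. Any claim that something is new, unique, unknown or untested is made for them only; others in the source may bear on it.

Compound 1, with the structure `C=CC(=O)Nc1cccc(Nc2ncnc(Nc3ccc(Oc4ccc(OC)cc4)cc3)n2)c1`, carries a 4-methoxyphenoxy group on one of its outer aromatic rings. In a functional assay on Raji cells (Homo sapiens) for antiproliferative activity, read by CCK-8 assay, with a stated time of 24 h (a higher number here means a weaker inhibitor, a lower number a stronger inhibitor), compound 1 gives "not determined" (no result reported), so its standing cannot be placed. A related molecule, compound 2 with the structure `C=CC(=O)Nc1cccc(Nc2nc(Cl)nc(Nc3ccc(Oc4ccccc4)cc3)n2)c1`, differs from compound 1 in two places at once, and in this assay compound 2 gives 15700 nM, a weak result. Compound 3, with the structure `C=CC(=O)Nc1cccc(Nc2ncnc(Nc3ccc(-c4ccc(C)nc4)cc3)n2)c1`, is the next variation: 6-methylpyridin-3-yl in place of 4-methoxyphenoxy on an aromatic carbon. For the measured compounds named here, because compound 1 has no value and no step between two measured compounds exists, the size and direction of this change cannot be read from the data; the only anchor is the weak result of compound 2. Compound 3 is therefore expected to land in a similarly weak region, estimated at 8000 nM, with a range from 1500 nM to 40000 nM.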

Compound 3, half-maximal inhibitory concentration: 13800 nM
Compound 3: the middle estimate sits 1.7-fold (0.24 log units) below what was measured; measured number inside the range.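

In this assay, for the compounds shown here, compound 1 gives "not determined" (no result reported) and compound 3 gives 13800 nM, so no step between compound 1 and compound 3 can be read. On these data alone, the effect of replacing 4-methoxyphenoxy with 6-methylpyridin-3-yl remains open. No evidence at hand bears on this result.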